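Anilide series in the writhing test: compound 2 to compound 4

A few compounds are considered here, and "the series" means these few. Any claim that something is new, unique, unknown or untested is made for them only; others in the source may bear on it.

Compound 1, `COc1cc2c(cc1OC)C(CC(=O)Nc1ccccc1)CC2`: 42.8%
Compound 2, `COc1cc2c(cc1OC)C(CC(=O)Nc1ccc(Br)cc1)CC2`: 37.5%
Compound 3, `COc1cc2c(cc1OC)C(CC(=O)Nc1ccccc1C)CC2`: 30%

All three numbers come from a functional assay on the whole organism (strain Swiss Albino) for inhibition, with Mus musculus as the target, in the writhing test, with a stated time of 1 h, at a dose of 100 mg/kg by the oral route; a lower number here means less inhibition, a higher number more inhibition at the dose given (going by the name of the read-out). Compound 2 holds the second highest of the three; its step from compound 1 is a number 5.3 percentage points lower from compound 1 to compound 2 (within the scatter) and the step on to compound 3 is a number 7.5 percentage points lower from compound 2 to compound 3 (within the scatter), both within the scatter, so no order among the three is claimed. Compound 4, `COc1cc2c(cc1OC)C(CC(=O)Nc1ccncc1)CC2`, differs from compound 2 by pyridin-4-yl in place of 4-bromophenyl on an amide-type nitrogen. Within the data shown here, two measured steps bear on this: the swap on the amide nitrogen, a number 7.5 percentage points lower from compound 2 to compound 3 (within the scatter), and the bromo for hydrogen change, a number 5.3 percentage points lower from compound 1 to compound 2 (within the scatter). Among the measured compounds shown here, neither left the scatter; the only step beyond it, a number 12.8 percentage points lower from compound 1 to compound 3 (beyond the scatter), is modest. For the measured compounds named here, no measured step places a pyridin-4-yl on the amide nitrogen. In this assay no step beyond the scatter is expected; the expected step is a number 0.5 percentage points higher from compound 2 to compound 4 (within the scatter). Compound 4 is estimated at 38%, between 24% and 52%.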

Compound 4, a percentage reported as inhibition, in the whole organism at one dose (the size of the read-out at that dose, not a potency): 60.1%
The estimate for compound 4 lay 22.1 percentage points below the measured number, and the stated range ends below it.
By their numbers in this assay, from the lowest: compounds 3, 2 and 1 (each within the scatter of the next, the first and the last beyond it); then compound 4.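

In this assay, among these compounds, pyridin-4-yl is the first group on the amide-type nitrogen to give a rise beyond the scatter, and it does so against all three earlier groups: phenyl (a number 17.3 percentage points higher from compound 1 to compound 4 (beyond the scatter)), 4-bromophenyl (a number 22.6 percentage points higher from compound 2 to compound 4 (beyond the scatter)) and 2-methylphenyl (a number 30.1 percentage points higher from compound 3 to compound 4 (beyond the scatter)). The earlier compounds shown here carried only rings of carbon, so this place responds to a change in the ring itself, not only to groups added to a phenyl ring. No evidence at hand accounts for the rise.

Going by these compounds, whether pyridin-3-yl, pyrimidin-5-yl or piperidin-4-yl on the amide-type nitrogen would match pyridin-4-yl remains open.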